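Replacing a short chain with a methoxyphenyl-bearing linker

A few compounds are considered here, and "the series" means these few. Any claim that something is new, unique, unknown or untested is made for them only; others in the source may bear on it.

The two compounds measured so far:
compound 1 `COc1ccc(CCCN2CCC(CNC(c3ccccc3)c3ccccc3)CC2)cc1` — 2800 nM
compound 2 `CCCN1CCC(COC(c2ccccc2)c2ccccc2)CC1` — 17800 nM

In a functional assay on cells (T-cell line, Homo sapiens) for inhibition (on this read-out higher numbers stand for weaker inhibition and lower numbers for stronger inhibition), compound 2 gives 17800 nM, the higher of the two numbers, while compound 1 gives 2800 nM, a gap that lies beyond the usual scatter. Going by the values given here, compound 1 carries a 4-methoxyphenyl group on its chain as well as a different link to the diphenylmethyl part, so the two measured compounds differ in more than one place and no single step between them can be stated.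

Compound 3 `COc1ccc(/C=C/CN2CCC(COC(c3ccccc3)c3ccccc3)CC2)cc1` is the next compound to be tested. Relative to compound 2 the change is 2-(4-methoxyphenyl)ethenyl in place of ethyl on a saturated chain carbon bound to an amine nitrogen in a ring. Since compound 1, which also bears a 4-methoxyphenyl group, gives the lower number, a downward step in this assay is expected for compound 3, of the size a 4.5-fold lower number from compound 2 to compound 3 (0.65 log units; beyond the scatter). Compound 3 is estimated at 4000 nM, likely between 1500 nM and 12000 nM.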

Compound 3, half-maximal inhibitory concentration: 4300 nM
The estimate for compound 3 lay 1.1-fold (0.03 log units) below the measured number, within the range that was stated.
By their numbers in this assay, from the lowest: compounds 1 and 3 (each within the scatter of the next); then compound 2.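

Going by these compounds alone, with the change from ethyl to 2-(4-methoxyphenyl)ethenyl on a saturated chain carbon bound to an amine nitrogen in a ring, this assay gives a 4.1-fold lower number from compound 2 to compound 3 (0.62 log units; beyond the scatter) and so offers the first comparison here in which only one place differs. This position therefore accepts a group of 10 heavy atoms, with an aromatic ring and a double bond, in place of one of 2, and the number falls rather than rises. Why the number falls remains unexplained, as nothing measured here bears on the cause.

The step covers the ring, the double bond and the methoxy group together, so their separate contributions cannot be told apart. Still open, from the compounds shown here alone, is how a plain 2-phenylethenyl group, without the methoxy, would compare, and whether an amine or a carboxylic acid on the aromatic ring would move the number.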